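The compounds below may be only part of what the source reports. "The series", "measured", "known", "first", "only" and "open" are said of these compounds alone.

Measured so far in a functional assay on MCF7 cells (Homo sapiens) for inhibition, read by MTT assay, with a stated time of 3 days; on this read-out lower numbers stand for stronger inhibition and higher numbers for weaker inhibition:
compound 1 `CC[C@H](C)[C@@H](NCC(=O)NNC(=O)COc1ccc(-c2nc3ccccc3s2)cc1OC)C(=O)O` — 1790 nM
compound 2 `CCOC(=O)[C@H](CCSC)NCC(=O)NNC(=O)COc1ccc(-c2nc3ccccc3s2)cc1OC` — 1760 nM

Going by the values given here, compound 1 holds the higher of the two numbers, but its only neighbour is compound 2, and the step of a 1.0-fold lower number from compound 1 to compound 2 (0.01 log units; within the scatter) lies within the scatter, so the two compounds stand level on this read-out.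

The step under consideration replaces the amino substituent of compound 1 to give compound 3 `CCOC(=O)[C@@H]1CCCN1CC(=O)NNC(=O)COc1ccc(-c2nc3ccccc3s2)cc1OC`: 2-(ethoxycarbonyl)pyrrolidin-1-yl in place of (1-carboxy-2-methylbutyl)amino on a saturated chain carbon bound to a carbonyl carbon.

Among the compounds with values here, only one measured step bears on it. The step of a 1.0-fold lower number from compound 1 to compound 2 (0.01 log units; within the scatter) also exchanged the whole substituent on the amine nitrogen, including the change from a carboxy group to an ethoxycarbonyl group, and left the number unchanged within the scatter. Compound 3 likewise carries an ethoxycarbonyl group, though here the nitrogen sits in a five-membered ring and both hydrogen-bond donors are lost. Within the data shown here, no step in this assay tests a ring closure of this kind. Among the measured compounds shown here, on the single step available, no change beyond the scatter is expected for compound 3, with a widened range to allow for the untested ring: a 1.0-fold higher number from compound 1 to compound 3 (0.00 log units; within the scatter). Compound 3 is therefore estimated at 1800 nM, expected to fall between 700 nM and 4500 nM.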

Compound 3, half-maximal inhibitory concentration: 770 nM
The estimate for compound 3 lay 2.3-fold (0.37 log units) above the measured number; the measured number falls inside the stated range.
By their numbers in this assay, from the lowest: compound 3; then compounds 2 and 1 (each within the scatter of the next).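

In this assay, the substituent on a saturated chain carbon bound to a carbonyl carbon now gives a change beyond the scatter: with 2-(ethoxycarbonyl)pyrrolidin-1-yl entering, the series shows a 2.3-fold lower number from compound 1 to compound 3 (0.37 log units; beyond the scatter) and also a 2.3-fold lower number from compound 2 to compound 3 (0.36 log units; beyond the scatter) as a modest gain. The ethoxycarbonyl group alone does not go with the lower number, since compound 2 carries it as well, so the open-chain amino substituents stand apart from the ring-bearing compound 3 on this read-out. No measurement on hand accounts for this difference.

Still open, from the compounds shown here alone, is whether the lower number belongs to the pyrrolidine ring alone or needs the ethoxycarbonyl group on it, which a pyrrolidin-1-yl bearing a carboxylic acid would address. A six-membered piperidin-1-yl at the same place would test whether the size of the ring matters.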